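Chloro in place of hydrogen on compound 1

The source may hold more compounds than are shown below. What is called first, only, known or untested is meant among the compounds shown, and "the series" means these compounds.

In a functional assay on NCI-H2228 cells (Homo sapiens) for inhibition, read by CellTiter-Glo, with a stated time of 96 h (a higher number here means a weaker inhibitor, a lower number a stronger inhibitor), compound 1 (`CC(C)S(=O)(=O)c1nn(C)cc1Nc1nc(Nc2ccc(C3CCN(C)CC3)cc2OC2CC2)ncc1Cl`) gives 36 nM, the second highest of three numbers. That lies within the scatter of compound 2 (`Cc1cc(Nc2ncc(Cl)c(Nc3cn(C)nc3S(=O)(=O)C(C)C)n2)c(OC2CC2)cc1C1CCCN(C)C1`) at 32 nM. Compound 3 (`CCNC(=O)c1cc(OC2CC2)c(Nc2ncc(Cl)c(Nc3cn(C)nc3S(=O)(=O)C(C)C)n2)cc1C`) gives 82 nM, beyond the scatter from compound 1. Compound 4 (`CC(C)S(=O)(=O)c1nn(C)cc1Nc1nc(Nc2cc(Cl)c(C3CCN(C)CC3)cc2OC2CC2)ncc1Cl`) keeps the core of compound 1, and the change is chloro in place of hydrogen on an aromatic carbon, ortho to a 1-methylpiperidin-4-yl group and para to a cyclopropyloxy group. Going by the values given here, the only measured step, a 2.6-fold higher number from compound 2 to compound 3 (0.41 log units; beyond the scatter), was modest and concerns a different group. Among the compounds with values here, no measured pair tests chloro, so no step beyond the scatter is expected in this assay, and no direction is favoured. The estimated step is a 1.1-fold lower number from compound 1 to compound 4 (0.05 log units; within the scatter). Compound 4 is expected at 32 nM, with an estimated range of 11 nM to 95 nM.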

Compound 4, half-maximal inhibitory concentration: 103 nM
Compound 4: the middle estimate sits 3.2-fold (0.51 log units) below what was measured; measured number above the stated range.
By their numbers in this assay, from the lowest: compounds 2 and 1 (each within the scatter of the next); then compounds 3 and 4 (each within the scatter of the next).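

In this assay, chloro in place of hydrogen on the aromatic carbon ortho to a 1-methylpiperidin-4-yl group and para to a cyclopropyloxy group gives a 2.9-fold higher number from compound 1 to compound 4 (0.46 log units; beyond the scatter) as a modest loss of activity. This position is therefore not neutral to substitution in this series, at least on the core of compound 1. As far as these compounds go, whether the loss is particular to chloro stays open, as a fluoro or methoxy group at this position would show. Nothing available accounts for the loss.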